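Cyclopentyl in place of 3-chloropropyl: the next compound

The compounds below may be only part of what the source reports. "The series", "measured", "known", "first", "only" and "open" are said of these compounds alone.

Compound 1 `O=c1nc2oc(CCCCCCCCCOCCCCCl)cc2cn1[C@H]1C[C@H](O)[C@@H](CO)O1` stands only at a limit in a functional assay on HEL cells (Homo sapiens); a lower number here means that less compound is tolerated, a higher number that more compound is tolerated: compound 1 gives > 200000 nM, the limit of the assay and not a number. Compound 2 `CCCCOCCCCCCCCCc1cc2cn([C@H]3C[C@H](O)[C@@H](CO)O3)c(=O)nc2o1` also reaches only the limit in this assay, at > 200000 nM. Compound 3 `CC(C)CCOCCCCCCCCCc1cc2cn([C@H]3C[C@H](O)[C@@H](CO)O3)c(=O)nc2o1` likewise sits at the limit, with > 200000 nM. The steps a step that the two limits leave unreadable from compound 1 to compound 2, a step that the two limits leave unreadable from compound 1 to compound 3 and a step that the two limits leave unreadable from compound 2 to compound 3 therefore cannot be sized, as the limit of > 200000 nM in this assay, at which 3 of the 3 values shown sit, records. Compound 4 `O=c1nc2oc(CCCCCCCCCOCC3CCCC3)cc2cn1[C@H]1C[C@H](O)[C@@H](CO)O1` differs from compound 1 by cyclopentyl in place of 3-chloropropyl on a saturated chain carbon bound to an oxygen on a saturated carbon. For the measured compounds named here, none of the measured steps gives a readable size for a change of this kind. Compound 4 is thus expected to stay at the limit as well, an expected step that the limit leaves unreadable from compound 1 to compound 4. The estimate for compound 4 is 300000 nM, expected between 150000 nM and 1000000 nM.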

Compound 4, half-maximal cytotoxic concentration: > 200000 nM
Compound 4: only a limit was reported (the forecaster's own chance of this, stated with the estimate: 85%); the middle value is on the limit's open side.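

In this assay compound 4 gives > 200000 nM, a limit and not a number. Its steps from compound 1, compound 2 and compound 3 cannot be read. The compounds shown leave open how far any of the four lies beyond the limit in this assay.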